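The compounds below may be only part of what the source reports. "The series", "measured", "known", "first", "only" and "open" are said of these compounds alone.

Compound 2 `CC(=O)OC/C(=C\c1ccc(Cl)cc1Cl)C(=O)c1ccccc1` has been measured in a functional assay on WiDr cells (Homo sapiens) for inhibition, read by sulforhodamine B assay, with a stated time of 48 h (a higher number here means a weaker inhibitor of growth, a lower number a stronger inhibitor of growth), where compound 2 gives 14000 nM. Among the two measured compounds this is the highest number, and the nearest neighbour is compound 1 `O=C(/C(=C/c1ccc(Cl)cc1Cl)CCl)c1ccccc1`: in this assay compound 1 gives 13000 nM. Among the measured compounds shown here, the only step measured so far, a 1.1-fold higher number from compound 1 to compound 2 (0.03 log units; within the scatter), swaps one group for another on a saturated chain carbon and leaves the number essentially where it was.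

Compound 3 `CC(=O)OC/C(=C/c1ccc(Cl)cc1Cl)C(=O)c1ccccc1` is the next compound to be tested. Its difference from compound 2 is the two compounds have the same atoms and bonds and differ only in configuration as drawn: 1 of 1 stereo elements differ; a double bond is drawn E in compound 2 and Z in compound 3. For the measured compounds named here, no measured step in this set concerns the geometry of the double bond; the single step that exists, from compound 1 to compound 2, changes a group rather than a configuration and lies within the scatter, so it offers no direct guide. With nothing pointing either way, the expectation for compound 3 in this assay is a step of no change at the digits printed from compound 2 to compound 3 (within the scatter), that is, no change beyond the scatter, with a wide range to reflect the uncertainty. Compound 3 is therefore expected to give 14000 nM in this assay, somewhere between 5000 nM and 40000 nM.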

Compound 3, concentration for 50% growth inhibition: 19000 nM
Beside the measured number, compound 3's estimate is 1.4-fold (0.13 log units) below it; measured number inside the range.
By their numbers in this assay, from the lowest: compounds 1, 2 and 3 (each within the scatter of the next).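

The double bond itself now comes under test for the first time, with the acetoxy group held in place, and the comparison is a clean one: the fact that compounds 2 and 3 differ only in the configuration as drawn

In this assay, the result is a 1.4-fold higher number from compound 2 to compound 3 (0.13 log units; within the scatter), so this read-out does not tell the two drawn geometries of the double bond apart. Together with a 1.1-fold higher number from compound 1 to compound 2 (0.03 log units; within the scatter), that gives two single changes around the same part of the molecule, one of a group on the saturated chain carbon and one of geometry, and neither step lies beyond the scatter.

The compounds shown leave open whether the two geometries would also read alike with a different group on that chain carbon, such as the chloro group of compound 1, an amine or a carboxylic acid, since the comparison exists only with acetoxy in place. They also leave open whether a change elsewhere on the shared core, for instance swapping the two chloro groups for methoxy groups, would shift the number beyond the scatter in this assay.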